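The source may report more compounds than this note shows. Statements on the series, on what has been measured and on what is new or still open speak of the compounds shown alone.

The series shares one core. Compound 1 `NC1=NC2(CCSCC2)N(OCCCOc2cccc(Cl)c2)C(N)=N1` carries a 3-chlorophenyl on an oxygen on a saturated carbon, compound 3 `NC1=NC2(CCSCC2)N(OCCCOc2ccc(Br)cc2)C(N)=N1` a 4-bromophenyl in that place, and compound 2 `Cc1ccc(OCCCON2C(N)=NC(N)=NC23CCOCC3)cc1` a 4-methylphenyl. In an assay on isolated protein for inhibition of Dihydrofolate reductase (Homo sapiens), read by spectrophotometry, using NADPH, with stated times of 5 s and 6 min, tested at 5 uM (on this read-out higher numbers stand for a stronger effect at the one concentration tested and lower numbers for a weaker effect), compound 1 gives 88.3%. Compound 3 sits at a limit of the assay, > 90%, not at a number. Compound 2 likewise stands at a limit, > 90%, so only a floor is known for it. For the measured compounds named here, the one measured step, a number at least 1.7 percentage points higher from compound 1 to compound 3 (that floor lies within the scatter), lies within the scatter, and two of the three values sit at the limit of > 90% in this assay, at which 2 of the 3 values shown sit. The unmeasured compound 4 `COc1ccc(OCCCON2C(N)=NC(N)=NC23CCOCC3)cc1` differs from compound 2 by methoxy in place of methyl on an aromatic carbon. Going by the values given here, no measured step exchanges methyl for methoxy on the aromatic ring, so the expectation rests on compound 2 standing at > 90%, which leaves little room upward. The step is expected to be a number no higher from compound 2 to compound 4 (the limit leaves the size open), none beyond the scatter. Compound 4 is therefore estimated at 90%, between 80% and 96%, and may again be reported only as a limit.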

Compound 4, a percentage reported as inhibition, at one concentration (the size of the read-out at that concentration, not a potency): > 90%
Compound 4: a limit, no number; the forecaster's own chance of this, stated with the estimate: 55%; the middle value lies on the limit itself.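

Compound 2 and compound 4 both stand at a limit in this assay, so no step can be read between them: the limit of > 90% in this assay, at which 3 of the 4 values shown sit.

The compounds shown leave open whether 4-methylphenyl and 4-methoxyphenyl differ at all in inhibition.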